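From a 3-nitrophenyl to a 4-cyanophenyl group in compound 3

This account rests on a few compounds, and the source may have more. Where it says the series, first, only, none or still open, it means among the compounds named here.

In an ADME assay on L02 cells (Homo sapiens) for cytotoxicity, read by MTT assay, with a stated time of 24 h (on this read-out higher numbers stand for weaker inhibition and lower numbers for stronger inhibition), compound 1 (`N#Cc1ccc(/C=C2\CN(S(=O)(=O)c3ccc(F)cc3)C/C(=C\c3ccc(C#N)cc3)C2=O)cc1`) gives 18900 nM. In this assay compound 2 (`COc1cc(/C=C2\CN(S(=O)(=O)c3ccc(F)cc3)C/C(=C\c3cccc([N+](=O)[O-])c3)C2=O)cc(OC)c1OC`) gives 18800 nM. These two values lie within the scatter of each other, so compound 2 stands level with compound 1 on the numbers available, and no order can be drawn between them.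

Compound 3 (`COc1cc(/C=C2\CN(S(=O)(=O)c3ccc(F)cc3)C/C(=C\c3ccc(C#N)cc3)C2=O)cc(OC)c1OC`) has not yet been measured. It differs from compound 2 in one place, on a double-bonded chain carbon bound to a double-bonded ring carbon: 4-cyanophenyl in place of 3-nitrophenyl on a double-bonded chain carbon bound to a double-bonded ring carbon. For the measured compounds named here, the incoming 4-cyanophenyl also occurs in compound 1, but compound 1 and compound 2 differ in more than one place, so no measured step isolates this change. The expectation therefore rests on the two values alone, which sit together although the compounds differ in structure. In this assay no step beyond the scatter is expected in either direction. The estimated change is a 1.0-fold lower number from compound 2 to compound 3 (0.02 log units; within the scatter), which would remain within the scatter. For compound 3 the expected value is 18000 nM, with an estimated range of 9000 nM to 36000 nM.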

Compound 3, half-maximal inhibitory concentration: 12900 nM
Estimate against measurement, compound 3: 1.4-fold (0.14 log units) above; low and high end bracket the measured number.
By their numbers in this assay, from the lowest: compounds 3, 2 and 1 (each within the scatter of the next).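

In this assay the exchange of 3-nitrophenyl for 4-cyanophenyl on a double-bonded chain carbon bound to a double-bonded ring carbon now has a measured step of its own, a 1.5-fold lower number from compound 2 to compound 3 (0.16 log units; within the scatter), and that step does not separate the two groups. The second step at this place, with 3,4,5-trimethoxyphenyl in place of 4-cyanophenyl, is a 1.5-fold lower number from compound 1 to compound 3 (0.17 log units; within the scatter), so it does not separate those two groups either, and all three aromatic groups seen here remain within the scatter in these single exchanges. Nothing measured here accounts for how closely these numbers sit together.

The compounds shown carry only these three groups at this place, so it stays open whether an amine, a carboxylic acid or a longer chain there would give a step beyond the scatter. From the compounds shown here alone, it is also open whether the same exchanges would stay within the scatter if the group on the sulfonyl were something other than 4-fluorophenyl, for instance a simple methyl, or a plain phenyl ring.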